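This account rests on a few compounds, and the source may have more. Where it says the series, first, only, none or still open, it means among the compounds named here.

Measured so far:
- compound 1 `Cc1cccc(C)c1S(=O)(=O)N1CCC[C@H]1[C@@H](O)CN1CCC[C@@]2(CCN(c3ncnc(N)c3C3CC3)C2)C1`: 690 nM
- compound 2 `Nc1ncnc(N2CC[C@@]3(CCCN(C[C@H](O)CNS(=O)(=O)c4ccccc4F)C3)C2)c1C1CC1`: 14000 nM

In an assay on LNCaP cells for inhibition of RAC-alpha serine/threonine-protein kinase (Homo sapiens) (a higher number here means a weaker inhibitor, a lower number a stronger inhibitor), compound 2 gives 14000 nM, the higher of the two numbers recorded, while compound 1 gives 690 nM. Compound 1 and compound 2 differ in more than one place, so the gap between them is noted only as what the two values show: compound 2 is the weaker inhibitor by a margin well beyond the usual scatter.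

Compound 3 `Cc1cc(F)ccc1S(=O)(=O)NC[C@@H](O)CN1CCC[C@@]2(CCN(c3ncnc(N)c3C3CC3)C2)C1` is not yet measured in this assay. It differs from compound 2 in one place: 4-fluoro-2-methylphenyl in place of 2-fluorophenyl on a sulfonyl sulfur. Among the compounds with values here, no single-place step between measured compounds is available to calibrate this exchange, so the expectation rests on the structural change alone and on the fact that compound 2 sits at the weak end of the series.

A modest gain is expected, within or just beyond the scatter, the step from compound 2 to compound 3 being estimated at a 2.0-fold lower number from compound 2 to compound 3 (0.30 log units; within the scatter). For compound 3 the expected value in this assay is 7000 nM, with a range from 2000 nM to 25000 nM.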

Compound 3, half-maximal inhibitory concentration: 2200 nM
Compound 3: the middle estimate sits 3.2-fold (0.50 log units) above what was measured; low and high end bracket the measured number.
By their numbers in this assay, from the lowest: compound 1; then compound 3; then compound 2.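

In this assay, 4-fluoro-2-methylphenyl in place of 2-fluorophenyl on a sulfonyl sulfur gives a 6.4-fold lower number from compound 2 to compound 3 (0.80 log units; beyond the scatter). Within the data shown here, this is the first single-place step, and it shows that the aryl group on the sulfonyl sulfur alone can shift the number beyond the scatter, with the rest of the structure unchanged and the two groups alike in their counted hydrogen-bond donors, acceptors and net charge. Nothing available bears on what lies behind the size of this step.

From the compounds shown here alone, the methyl and the fluorine of 4-fluoro-2-methylphenyl are not separated by these compounds, and it remains open how a plain phenyl, a phenyl carrying a nitrile or a phenyl carrying a carboxylic acid on the same sulfonyl sulfur would read in this assay. Going by these compounds, compound 1, at 690 nM, differs from compound 3 in more than one place, so the share of any single change in the gap between those two values also remains open.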